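The compounds below may be only part of what the source reports. "The series", "measured", "known", "first", "only" and "open" are said of these compounds alone.

Compound 2 `Cc1c(C(=O)Nc2ccc(Oc3ncnc4[nH]cc(-c5ccccc5)c34)c(F)c2)c(=O)c2cc(C3CC3)ccc2n1C` is the weaker of the two compounds measured in an assay on isolated protein for inhibition of tyrosine-protein kinase receptor UFO (Homo sapiens), read by FRET and Z'-LYTE, with a stated time of 1.5 h (on this read-out higher numbers stand for weaker inhibition and lower numbers for stronger inhibition), where compound 2 gives 230 nM. Its nearest neighbour, compound 1 `CCc1ccc2c(c1)c(=O)c(C(=O)Nc1ccc(Oc3ncnc4[nH]cc(-c5ccccc5)c34)c(F)c1)c(C)n2C`, gives 6 nM; the only difference is cyclopropyl in place of ethyl on an aromatic carbon, and that single step brought a 38-fold higher number from compound 1 to compound 2 (1.58 log units; beyond the scatter). Compound 3 `Cc1c(C(=O)Nc2ccc(Oc3ncnc4[nH]cc(-c5ccccc5)c34)c(F)c2)c(=O)c2cc(C(C)C)ccc2n1C` changes the same position again: isopropyl in place of cyclopropyl on an aromatic carbon. Among the compounds with values here, the step from ethyl to cyclopropyl is the only evidence that bears on it, and since isopropyl, like ethyl, has no ring, the number is expected to move back part of the way, giving a 3.3-fold lower number from compound 2 to compound 3 (0.52 log units; beyond the scatter). Compound 3 is therefore estimated at 70 nM, in a range from 15 nM to 300 nM.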

Compound 3, half-maximal inhibitory concentration: 26 nM
The estimate for compound 3 lay 2.7-fold (0.43 log units) above the measured number; the measured number falls inside the stated range.
By their numbers in this assay, from the lowest: compound 1; then compound 3; then compound 2.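

In this assay, isopropyl and cyclopropyl have the same count of heavy atoms, yet replacing the ring with the open branch gives an 8.8-fold lower number from compound 2 to compound 3 (0.95 log units; beyond the scatter), so that count alone does not set the number at this position. Adding a single methyl to the ethyl group also matters, with a 4.3-fold higher number from compound 1 to compound 3 (0.64 log units; beyond the scatter), and ethyl remains the best of the three groups. Nothing measured here gives a reason for these differences. As far as these compounds go, whether a methoxy group, an amine or a longer chain such as propyl would match or improve on ethyl remains open.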